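This account rests on a few compounds, and the source may have more. Where it says the series, first, only, none or still open, it means among the compounds named here.

Measured in a functional assay on the whole organism (strain albino) for inhibition, with Rattus norvegicus as the target, read by paw edema, with a stated time of 2 h, at a dose of 0.28 mmol/kg by the oral route; a higher number here means more inhibition at the dose given (going by the name of the read-out), a lower number less inhibition:

compound 1 `C=CCn1c(SCC(=O)c2ccccc2)nnc1-c1ccccc1` — compound 1 gives 58%
compound 2 `O/N=C(/CSc1nnc(-c2ccccc2)n1-c1ccccc1)c1ccccc1` — compound 2 gives 63%
compound 3 `C=CCn1c(SC/C(=N/O)c2ccccc2)nnc1-c1ccc(OC)cc1` — compound 3 gives 66%

The three compounds share a core and differ in the group on the ring nitrogen, in the substitution of the phenyl on the core, and in whether the side chain carries a carbonyl or an oxime. Of the three numbers in this assay, that of compound 1 is the smallest, but the gap to compound 2 and the gap to compound 3 both lie within the usual scatter, so none of the three is separated from the others on these numbers.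

Compound 4 `CCn1c(SCC(=O)c2ccccc2)nnc1-c1ccccc1` has not been measured. It differs from compound 1 in one place: methyl in place of vinyl on a saturated chain carbon bound to an aromatic nitrogen. Within the data shown here, no pair of measured compounds in this set differs in one place, so there is no measured step to lean on for the size of this change. The change removes one carbon from a short chain on the ring nitrogen and leaves the rest of the molecule as in compound 1. Among the measured compounds shown here, with no step of this kind measured, the expectation for compound 4 is a step no larger than the scatter in this assay, in no firm direction, a step of a number 2 percentage points lower from compound 1 to compound 4 (within the scatter). Compound 4 is therefore estimated at 56%, with a range from 44% to 68%.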

Compound 4, a percentage reported as inhibition, in the whole organism at one dose (the size of the read-out at that dose, not a potency): 55%
Beside the measured number, compound 4's estimate is 1 percentage points above it, and the stated range covers the measured number.
By their numbers in this assay, from the lowest: compounds 4, 1, 2 and 3 (each within the scatter of the next, the first and the last beyond it).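

Among these compounds, this is the first step that can be read at a single place: in this assay, exchanging allyl for ethyl on the aromatic nitrogen gives a step of a number 3 percentage points lower from compound 1 to compound 4 (within the scatter) and so does not separate the pair. In this pair, then, losing the double bond outside aromatic rings and shortening the chain by one carbon leave inhibition at this dose within the scatter. Nothing at hand bears on the reason for this outcome.

As far as these compounds go, it remains open whether a longer chain such as butyl, a benzyl group or a chain ending in an amine at this place would move the number beyond the scatter. From the compounds shown here alone, it is also open whether allyl and ethyl would stay this close with an oxime in the side chain, as in compound 3.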